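Phenyl group change from compound 2 to compound 3

This account rests on a few compounds, and the source may have more. Where it says the series, first, only, none or still open, it means among the compounds named here.

Measured in an ADME assay on microsomes from liver (Rattus norvegicus) for metabolic stability (a lower number here means that the compound disappears faster, a higher number that the compound lasts longer), so far
compound 1 (`Nc1nc(NCCNc2ncc(-c3ncc[nH]3)c(-c3ccc(F)cc3Br)n2)ccc1[N+](=O)[O-]`) gives > 0.5 h
compound 2 (`Nc1nc(NCCNc2ncc(-c3ncc[nH]3)c(-c3ccc(F)cc3C(F)(F)F)n2)ccc1[N+](=O)[O-]`) gives > 0.5 h

Compound 2 stands at > 0.5 h in this assay and this is a limit, not a number. Compound 1 stands at > 0.5 h and this is also a limit. Both readings sit at the same bound (the limit of > 0.5 h in this assay, at which 2 of the 2 values shown sit).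

Compound 3 (`Nc1nc(NCCNc2ncc(-c3ncc[nH]3)c(-c3ccc(Br)cc3Cl)n2)ccc1[N+](=O)[O-]`) carries 4-bromo-2-chlorophenyl in place of 4-fluoro-2-(trifluoromethyl)phenyl on an aromatic carbon. Going by the values given here, the one measured step that bears on this change is a step that the two limits leave unreadable from compound 1 to compound 2 and it also concerns this phenyl group. Its size cannot be read, so it offers no direction, and no step beyond the scatter is expected in this assay. The expected step is a step that the limit leaves unreadable from compound 2 to compound 3 in this estimate. For compound 3 the estimated value is 0.6 h within an expected range of 0.3 h to 1.2 h in this assay's read-out.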

Compound 3, half-life: > 0.5 h
Compound 3: no number, only a limit; the forecaster's own chance of this, stated with the estimate: 60%; the middle value does not contradict the limit.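

Neither the step between compound 2 and compound 3 nor the step between compound 1 and compound 3 can be read in this assay, because all three compounds sit at one limit: the limit of > 0.5 h in this assay, at which 3 of the 3 values shown sit.

The compounds shown leave open whether these phenyl groups differ at all in this assay, and what the actual half-life of each compound is.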